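This account rests on a few compounds, and the source may have more. Where it says the series, first, only, none or still open, it means among the compounds named here.

Compound 2 `CCCCCC/C=C1\S/C(=N\c2csc(-c3ccc(Cl)cc3)c2)NC1=O` is one of two compounds tested in a functional assay on HT-29 cells (Homo sapiens) for cytotoxicity, read by MTT assay, with a stated time of 72 h; a lower number here means a stronger inhibitor, a higher number a weaker inhibitor. In this assay compound 2 gives 33500 nM, the higher of the two numbers. For the measured compounds named here, its only neighbour, compound 1 `O=C1N/C(=N/c2csc(-c3ccc(Cl)cc3)c2)S/C1=C\c1ccccc1`, gives in this assay 10500 nM. The two differ in a single place, the group on a double-bonded chain carbon bound to a double-bonded ring carbon, and the step of a 3.2-fold higher number from compound 1 to compound 2 (0.50 log units; beyond the scatter) shows what exchanging phenyl for hexyl did to the number.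

Compound 3 `O=C1N/C(=N/c2csc(-c3ccc(Cl)cc3)c2)S/C1=C\c1ccc(F)cc1` has not yet been measured. It differs from compound 2 in one place: 4-fluorophenyl in place of hexyl on a double-bonded chain carbon bound to a double-bonded ring carbon. Going by the values given here, this is nearly the reverse of the one measured step: the hexyl goes out and an aromatic ring returns, now carrying a fluorine. The step of a 3.2-fold higher number from compound 1 to compound 2 (0.50 log units; beyond the scatter) therefore bears directly on it, and it is expected to run backwards, towards a lower number, by a similar margin. Nothing measured here tells how the added fluorine shifts that picture; the estimate is therefore anchored to compound 1 and its value of 10500 nM. For compound 3 the expected step is a 3.4-fold lower number from compound 2 to compound 3 (0.53 log units; beyond the scatter). Compound 3 is estimated at 10000 nM in this assay, within a range from 4000 nM to 25000 nM.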

Compound 3, half-maximal inhibitory concentration: 4100 nM
Beside the measured number, compound 3's estimate is 2.4-fold (0.39 log units) above it, within the range that was stated.
By their numbers in this assay, from the lowest: compound 3; then compound 1; then compound 2.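

In this assay the new compound gives a second aromatic ring to compare with the hexyl chain: 4-fluorophenyl in place of hexyl produces an 8.2-fold lower number from compound 2 to compound 3 (0.91 log units; beyond the scatter), so both aromatic compounds now give lower numbers than the one compound with a chain, and no compound shown goes against this. The result also shows that this place responds to a much smaller edit than exchanging a chain for a ring, since fluoro in place of hydrogen on an aromatic carbon gives a 2.6-fold lower number from compound 1 to compound 3 (0.41 log units; beyond the scatter), a change beyond the scatter from one added atom. There is no evidence here to explain why either exchange lowers the number.

Going by these compounds, whether this gain is particular to fluorine remains open, as a chlorine or a methoxy group on the same ring might move the number in the same direction, by a different amount, or not at all. On these data alone, it is also open whether a shorter chain such as propyl, or a saturated ring such as cyclohexyl, would fall with hexyl or with the aromatic compounds.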